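Indanyl in place of dichlorophenyl on a urea nitrogen

The compounds below may be only part of what the source reports. "The series", "measured", "known", "first", "only" and "open" are said of these compounds alone.

Of the compounds shown here, three have been measured for antiproliferative activity. Compound 1 `COc1cc(OC)c2c(=O)cc(C(=O)Nc3ccc(-n4cccc4)cc3)[nH]c2c1` carries an amide on the shared core. In a functional assay on KOPN-8 cells (Homo sapiens) for antiproliferative activity, with a stated time of 72 h (a lower number here means that less compound is needed, a higher number that more compound is needed for the effect), compound 1 reaches only the limit of the assay, > 77000 nM. Compound 2 `COC(=O)c1cc(=O)c2cc(NC(=O)Nc3ccc(Cl)c(C(F)(F)F)c3)ccc2[nH]1` carries a urea instead. In this assay compound 2 also gives only a limit, > 6350 nM. Compound 3 `COC(=O)c1cc(=O)c2cc(NC(=O)Nc3ccc(Cl)c(Cl)c3)ccc2[nH]1` differs from compound 2 by chloro in place of trifluoromethyl on an aromatic carbon. In this assay compound 3 likewise gives only a limit, > 6350 nM.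

The step that the two limits leave unreadable from compound 2 to compound 3 cannot be read because both compounds sit at the limit of > 6350 nM in this assay, at which 2 of the 3 values shown sit. Compound 3 therefore stands at the same limit as compound 2, while compound 1 sits at the limit of > 77000 nM in this assay, at which 1 of the 3 values shown sits; no ordering among the three can be drawn.

Compound 4 `COC(=O)c1cc(=O)c2cc(NC(=O)Nc3ccc4c(c3)CCC4)ccc2[nH]1` is not yet measured. It differs from compound 3 by 2,3-dihydro-1H-inden-5-yl in place of 3,4-dichlorophenyl on an amide-type nitrogen. Going by the values given here, the only measured step that touches this urea series is the unreadable one from compound 2 to compound 3, so no step size offers guidance beyond the fact that every measured value is a limit. Compound 4 is therefore expected to give about 12000 nM in this assay, within a range from 3000 nM to 60000 nM. The expected step that the limit leaves unreadable from compound 3 to compound 4 is accordingly not expected to stand out beyond the scatter.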

Compound 4, half-maximal effective concentration: > 24100 nM
Compound 4 was reported as a limit (the forecaster's own chance of this, stated with the estimate: 65%); middle value at least 2.0-fold (0.30 log units) away from the limit.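

In this assay compound 3 and compound 4 are both reported only as limits, so the step between them cannot be read. The compounds shown leave open whether 2,3-dihydro-1H-inden-5-yl in place of 3,4-dichlorophenyl on the amide-type nitrogen alters antiproliferative activity, and whether any of the four compounds reaches a readable value.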